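Methylation of a catechol hydroxyl in the oxadiazole hydrazone series

This account rests on a few compounds, and the source may have more. Where it says the series, first, only, none or still open, it means among the compounds named here.

Three members of the series have been tested in a functional assay on SW 1116 cells (Homo sapiens) for cytotoxicity, read by MTT assay, with a stated time of 48 h; on this read-out higher numbers stand for weaker inhibition and lower numbers for stronger inhibition. Compound 1 `O=C(CSc1nnc(-c2ccncc2)o1)N/N=C/c1ccc(O)cc1` gives 12200 nM. Compound 2 `COc1ccc(/C=N/NC(=O)CSc2nnc(-c3ccncc3)o2)cc1`, which differs by methyl in place of hydrogen on an oxygen on an aromatic ring, gives 20300 nM; the step of a 1.7-fold higher number from compound 1 to compound 2 (0.22 log units; within the scatter) is therefore small. Compound 3 `O=C(CSc1nnc(-c2ccncc2)o1)N/N=C/c1ccc(O)c(O)c1` differs from compound 1 by hydroxy in place of hydrogen on an aromatic carbon; in this assay compound 3 gives 1540 nM, and the steps of a 7.9-fold lower number from compound 1 to compound 3 (0.90 log units; beyond the scatter) and a 13-fold lower number from compound 2 to compound 3 (1.12 log units; beyond the scatter) mark it as the compound with the lowest number of the three.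

Compound 4 `COc1cc(/C=N/NC(=O)CSc2nnc(-c3ccncc3)o2)ccc1O` has not been measured. It differs from compound 3 by methyl in place of hydrogen on an oxygen on an aromatic ring. Going by the values given here, this is the same change as the one from compound 1 to compound 2, made at a place described in identical terms; the two cores differ by hydroxy in place of hydrogen on an aromatic carbon, so the methyl in compound 4 sits on an oxygen of a ring that also carries the added hydroxy group.

Because the earlier step of a 1.7-fold higher number from compound 1 to compound 2 (0.22 log units; within the scatter) stayed within the scatter, the expectation for compound 4 is a step of similar size, a 1.7-fold higher number from compound 3 to compound 4 (0.23 log units; within the scatter), in this assay. This rests on a single precedent and on the assumption that the second hydroxy group does not alter the outcome of methylation. Compound 4 is estimated at 2600 nM, with the range 1000 nM to 7000 nM allowing for the possibility that the step is somewhat larger than that seen from compound 1 to compound 2.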

Compound 4, half-maximal inhibitory concentration: 3590 nM
Compound 4: middle estimate off by 1.4-fold (0.14 log units), on the low side, and the stated range covers the measured number.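

In this assay, methylation of the hydroxy oxygen behaves alike on the two cores available, and the two steps cannot be told apart: the same change on two cores in this assay, a 1.7-fold higher number (0.22 log units; within the scatter) from compound 1 to compound 2 and a 2.3-fold higher number (0.37 log units; beyond the scatter) from compound 3 to compound 4, 1.4-fold (0.15 log units) apart, within the scatter of two such steps The new step, a 2.3-fold higher number from compound 3 to compound 4 (0.37 log units; beyond the scatter), lies beyond the scatter where the earlier one did not, but that contrast in labels is no evidence of a difference between the cores, and compound 4 still retains a lower number than either compound lacking its extra ring substituent, with a 5.7-fold lower number from compound 2 to compound 4 (0.75 log units; beyond the scatter) and a 3.4-fold lower number from compound 1 to compound 4 (0.53 log units; beyond the scatter). This supports carrying the change from the core of compound 1 to the core of compound 3 in this cell assay, but it rests on two pairs and does not show that the step would keep its size on any other core.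

Still open, from the compounds shown here alone, is whether a longer chain on the same oxygen, such as ethyl, would continue the trend of these two methyl steps or depart from it. Going by these compounds, it is equally open whether an amine or a fluorine in place of the hydroxy group would retain the lower numbers seen with compound 3 and compound 4.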